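A few compounds are considered here, and "the series" means these few. Any claim that something is new, unique, unknown or untested is made for them only; others in the source may bear on it.

Series notes, thienyl aminoketones with a piperazine arm, read in an assay on CHO cells for displacement of a labelled ligand from adenosine receptor A3 (Homo sapiens), read by scintillation counting, with a stated time of 120 min, tested at 10 uM; a lower number here means less inhibition, a higher number more inhibition at the concentration tested (going by the name of the read-out).

Measured so far:
compound 1 `CC(C)N1CCN(Cc2csc(N)c2C(=O)c2ccc(Cl)cc2)CC1`: 0%
compound 2 `Nc1scc(CN2CCN(c3ccc(Cl)cc3Cl)CC2)c1C(=O)c1ccc(Cl)cc1`: 0%
compound 3 `Nc1scc(CN2CCN(c3ccc([N+](=O)[O-])cc3)CC2)c1C(=O)c1ccc(Cl)cc1`: 2%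

Taken as written, compound 3 carries the numerically largest of the three values, but the steps of a number 2 percentage points higher from compound 1 to compound 3 (within the scatter) and a number 2 percentage points higher from compound 2 to compound 3 (within the scatter) both lie within the scatter, so nothing separates compound 3 from compound 1 or compound 2; the whole set reads as flat at the concentration tested.

Next in line is compound 4 `Nc1scc(CN2CCN(c3ccc(Cl)c(C(F)(F)F)c3)CC2)c1C(=O)c1ccc(Cl)cc1`. Relative to compound 3 the difference is 4-chloro-3-(trifluoromethyl)phenyl in place of 4-nitrophenyl on an amine nitrogen in a ring.

Every measured step bears on this change, since each exchanges the group on the same ring nitrogen: no change at the digits printed from compound 1 to compound 2 (within the scatter), a number 2 percentage points higher from compound 1 to compound 3 (within the scatter) and a number 2 percentage points higher from compound 2 to compound 3 (within the scatter). Isopropyl, 2,4-dichlorophenyl and 4-nitrophenyl at that position all give essentially no inhibition, and none of the exchanges moved the read-out beyond the scatter. A further aryl swap at the same nitrogen is therefore expected to bring no step beyond the scatter, which is what no change at the digits printed from compound 3 to compound 4 (within the scatter) expresses. For compound 4 the expected value in this assay is 2%, with a range of 0% to 12%.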

Compound 4, a percentage reported as inhibition, at one concentration (the size of the read-out at that concentration, not a potency): 3%
Compound 4: the middle estimate sits 1 percentage points below what was measured, and the stated range covers the measured number.
By their numbers in this assay, from the lowest: compounds 1, 2, 3 and 4 (each within the scatter of the next).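

In this assay the exchange of 4-nitrophenyl for 4-chloro-3-(trifluoromethyl)phenyl on the amine nitrogen in the ring brings no separation (a number 1 percentage points higher from compound 3 to compound 4 (within the scatter)), so an aryl group with 0 hydrogen-bond acceptors and 11 heavy atoms reads the same as one with 2 hydrogen-bond acceptors and 9 heavy atoms. The same holds when compound 4 is set against the compounds carrying 2,4-dichlorophenyl (a number 3 percentage points higher from compound 2 to compound 4 (within the scatter)) and isopropyl (a number 3 percentage points higher from compound 1 to compound 4 (within the scatter)), which leaves all four groups at this nitrogen, aromatic or not, within the scatter of one another at the concentration tested. No measurement at hand gives a reason for this flat reading.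

The compounds shown leave open whether a carboxylic acid or a primary amine on the aryl ring, or a longer chain in place of isopropyl, would lift the read-out beyond the scatter. Also open, going by these compounds, is whether any change away from this nitrogen, such as an amide in place of the ketone carbonyl or a replacement of the 4-chlorophenyl group, would do so, as all four compounds keep those parts unchanged.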